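This account rests on a few compounds, and the source may have more. Where it says the series, first, only, none or still open, it means among the compounds named here.

Working notes on the series.

Among the compounds with values here, compound 3 `CCCc1cncc(OC[C@@H]2CCN2)c1` sits at the low end of the numbers so far: in an assay on brain for binding affinity to Neuronal acetylcholine receptor; alpha4/beta2 (Rattus norvegicus), read by radioligand binding (a lower number here means a stronger inhibitor, a higher number a weaker inhibitor), compound 3 gives 0.039 nM. Its nearest neighbour is compound 1 `Nc1cncc(OC[C@@H]2CCN2)c1`, for which compound 1 gives 0.082 nM; furthest is compound 2 `CCc1cncc(OC[C@@H]2CCN2)c1`, where compound 2 gives 0.1 nM. The step of a 2.1-fold lower number from compound 1 to compound 3 (0.32 log units; beyond the scatter) and the step of a 2.6-fold lower number from compound 2 to compound 3 (0.41 log units; beyond the scatter) are both modest but beyond the scatter, whereas a 1.2-fold higher number from compound 1 to compound 2 (0.09 log units; within the scatter) stays within it.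

Compound 4 `O=[N+]([O-])c1cncc(OC[C@@H]2CCN2)c1` differs from compound 3 by nitro in place of propyl on an aromatic carbon. Within the data shown here, no measured pair swaps propyl for nitro, so the change is read only against the same aromatic carbon: amino, ethyl and propyl there moved the numbers by at most a modest step, and compound 1 with amino sits within a modest step of compound 3. The expectation for compound 4 in this assay is therefore a small rise in the number, a 2.1-fold higher number from compound 3 to compound 4 (0.31 log units; beyond the scatter), toward the level of compound 1 at 0.082 nM. Compound 4 is estimated at 0.08 nM, with a range of 0.03 nM to 0.25 nM.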

Compound 4, inhibition constant: 0.33 nM
Beside the measured number, compound 4's estimate is 4.1-fold (0.62 log units) below it, outside the stated range (above it).
By their numbers in this assay, from the lowest: compound 3; then compounds 1 and 2 (each within the scatter of the next); then compound 4.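

Within the data shown here, at the aromatic carbon two atoms from the ring nitrogen, nitro is the first group to separate clearly from the rest in this assay: it gives an 8.5-fold higher number from compound 3 to compound 4 (0.93 log units; beyond the scatter), a 4.0-fold higher number from compound 1 to compound 4 (0.60 log units; beyond the scatter) and a 3.3-fold higher number from compound 2 to compound 4 (0.52 log units; beyond the scatter), so the position is less tolerant than amino, ethyl and propyl alone suggested. Nitro and propyl have the same heavy-atom count, yet this swap gives the largest step in the series, so that count alone does not set the number here. Nothing available explains the loss.

From the compounds shown here alone, it remains open whether a nitrile or a carboxylic acid on this carbon would track with nitro or stay with the amino, ethyl and propyl compounds. A longer chain such as butyl would show whether the level of compound 3 can be passed.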